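Chloro to methyl on the 3-chlorophenyl analogue

A few compounds are considered here, and "the series" means these few. Any claim that something is new, unique, unknown or untested is made for them only; others in the source may bear on it.

Measured in a functional assay on SGC-7901 cells (Homo sapiens) for antiproliferative activity, read by MTT assay, with a stated time of 72 h; a lower number here means a stronger inhibitor, a higher number a weaker inhibitor:
- compound 1 `COc1cc(-n2cnc3ccc(-c4ccc(C(C)=O)cc4)cc32)cc(OC)c1OC` gives 450 nM
- compound 2 `COc1cc(-n2cnc3ccc(-c4cc(F)ccc4F)cc32)cc(OC)c1OC` gives 6590 nM
- compound 3 `COc1cc(-n2cnc3ccc(-c4cccc(Cl)c4)cc32)cc(OC)c1OC` gives 1490 nM

Compound 3 holds the second highest of the three numbers (1490 nM). Compound 4 `COc1cc(-n2cnc3ccc(-c4cccc(C)c4)cc32)cc(OC)c1OC` carries methyl in place of chloro on an aromatic carbon, meta to a large group (methyl in place of chloro on an aromatic carbon). Going by the values given here, no measured step isolates this exchange. The closest evidence comes from replacing the whole aryl group: a 3.3-fold higher number from compound 1 to compound 3 (0.52 log units; beyond the scatter) and a 4.4-fold lower number from compound 2 to compound 3 (0.65 log units; beyond the scatter) are modest, while a 15-fold higher number from compound 1 to compound 2 (1.17 log units; beyond the scatter) is large. None of these compares methyl with chloro, so no step beyond the scatter is expected in this assay and no direction is favoured. The expected change is a 1.0-fold higher number from compound 3 to compound 4 (0.00 log units; within the scatter). Compound 4 is estimated at 1500 nM with an expected range from 600 nM to 3700 nM.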

Compound 4, half-maximal inhibitory concentration: 1240 nM
Estimate against measurement, compound 4: 1.2-fold (0.08 log units) above; measured number inside the range.
By their numbers in this assay, from the lowest: compound 1; then compounds 4 and 3 (each within the scatter of the next); then compound 2.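

In this assay, methyl and chloro on this aromatic carbon are not told apart (a 1.2-fold lower number from compound 3 to compound 4 (0.08 log units; within the scatter)). Compound 4 stands against the other two aryl groups much as compound 3 does, with a 5.3-fold lower number from compound 2 to compound 4 (0.73 log units; beyond the scatter) and a 2.8-fold higher number from compound 1 to compound 4 (0.44 log units; beyond the scatter), so the gaps to those compounds follow the whole aryl exchange and not this atom. No measurement here offers an explanation for these steps.

Open, as far as these compounds go, is how an amine, a carboxylic acid or a longer chain would read at this place on the ring. Also open is whether the 4-acetylphenyl result depends on the acetyl group itself, as no compound shown isolates it.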